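A few compounds are considered here, and "the series" means these few. Any claim that something is new, unique, unknown or untested is made for them only; others in the source may bear on it.

Compound 1 `CC(O)(COc1cccc(S(F)(F)(F)(F)F)c1)C(=O)Nc1ccc(C(F)(F)F)cc1` gives 12800 nM in a functional assay on LNCaP cells (Homo sapiens) for antiproliferative activity, read by propidium iodide staining, with a stated time of 96 h; a higher number here means a weaker inhibitor, a lower number a stronger inhibitor. Compound 3 `CC(O)(COc1cccc(C(F)(F)C(F)(F)F)c1)C(=O)Nc1ccc(C(F)(F)F)cc1` keeps the core of compound 1 and differs from it by a group of 7 heavy atoms (2 carbon, 5 fluorine; no ring) in place of a group of 6 heavy atoms (5 fluorine, 1 sulfur; no ring), on an aromatic carbon. In this assay compound 3 gives 3900 nM, so this change made a 3.3-fold lower number from compound 1 to compound 3 (0.52 log units; beyond the scatter). Compound 2 `CC(O)(COc1ccc(S(F)(F)(F)(F)F)cc1)C(=O)Nc1cc(C(F)(F)F)cc(C(F)(F)F)c1` is built on another core; the difference between the two cores is not broken down here. In this assay compound 2 gives 1900 nM, the lowest of the three numbers.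

Compound 4 `CC(O)(COc1ccc(C(F)(F)C(F)(F)F)cc1)C(=O)Nc1cc(C(F)(F)F)cc(C(F)(F)F)c1` has not been measured. It differs from compound 2 by a group of 7 heavy atoms (2 carbon, 5 fluorine; no ring) in place of a group of 6 heavy atoms (5 fluorine, 1 sulfur; no ring), on an aromatic carbon. Within the data shown here, this is the same kind of change as the one from compound 1 to compound 3, not the same change: in compound 3 the entering group sits meta to a large group, in compound 4 it sits para to a large group. Among the measured compounds shown here, the step is expected to be a 2.5-fold lower number from compound 2 to compound 4 (0.40 log units; beyond the scatter), a little smaller than the earlier one, because the same kind of change at the other place made a 3.3-fold lower number from compound 1 to compound 3 (0.52 log units; beyond the scatter) and only one such example exists. Compound 4 is therefore expected to give about 750 nM in this assay, likely between 300 nM and 1900 nM.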

Compound 4, half-maximal inhibitory concentration: 2700 nM
The estimate for compound 4 lay 3.6-fold (0.56 log units) below the measured number, outside the stated range (above it).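

On the core of compound 2, placing 1,1,2,2,2-pentafluoroethyl where the group of sulfur and five fluorines stood gave a 1.4-fold higher number from compound 2 to compound 4 (0.15 log units; within the scatter) in this assay, so on this core the swap makes no clear difference. Set beside the earlier step, the change did not carry over unchanged from one core to the other: the same change on two cores in this assay, a 3.3-fold lower number (0.52 log units; beyond the scatter) from compound 1 to compound 3 and a 1.4-fold higher number (0.15 log units; within the scatter) from compound 2 to compound 4, 4.7-fold (0.67 log units) apart, beyond the scatter of two such steps. Among these compounds, the lower number seen on the core of compound 1 therefore cannot simply be expected on another core, but the result does not show which difference between the cores matters, as they differ in more than one place and each offers only one pair.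

Still open, going by these compounds, is how the swap behaves when only the position of the group on its ring changes and the rest of the core stays the same. Also open, on these data alone, is whether either step would hold with a nitrile or a chlorine atom in place of the trifluoromethyl groups on the other ring.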